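The source may hold more compounds than are shown below. What is called first, only, known or untested is meant among the compounds shown, and "the series" means these compounds.

Measured so far in a physicochemical assay for solubility, at pH 7; a higher number here means a more soluble compound, a lower number a less soluble compound:
- Compound 1 `CN1CCC(C(=O)N2Cc3c(NC(=O)c4ccc5ccccc5c4)n[nH]c3C2(C)C)CC1`: 219000 nM
- Compound 2 `CN1CCC(C(=O)N2Cc3c(NC(=O)c4cc(F)cc(F)c4)n[nH]c3C2(C)C)CC1`: > 225000 nM (a limit of the assay, not a number)
- Compound 3 `CN1CCC(C(=O)N2Cc3c(NC(=O)c4ccc(Cl)cc4)n[nH]c3C2(C)C)CC1`: > 225000 nM (a limit of the assay, not a number)

Compound 3 has no exact reading and stands at the limit of > 225000 nM in this assay, at which 2 of the 3 values shown sit. Compound 4 `CN1CCC(C(=O)N2Cc3c(NC(=O)c4cccs4)n[nH]c3C2(C)C)CC1` is still unmeasured. It differs from compound 3 as follows: thiophen-2-yl in place of 4-chlorophenyl on a carbonyl carbon. In short, thiophen-2-yl sits in place of 4-chlorophenyl on a carbonyl carbon.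

Three measured steps change the group at this same place. They are an at least 1.0-fold higher number from compound 1 to compound 2 (0.01 log units; that floor lies within the scatter), an at least 1.0-fold higher number from compound 1 to compound 3 (0.01 log units; that floor lies within the scatter) and a step that the two limits leave unreadable from compound 2 to compound 3. None of them shows a size beyond the scatter, so no step beyond the scatter is expected in this assay, in either direction. The expected step is an at least 1.0-fold lower number from compound 3 to compound 4 (0.00 log units; that floor lies within the scatter). Compound 4 is estimated at 220000 nM. The expected range for compound 4 runs from 140000 nM to 240000 nM.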

Compound 4, solubility: 155000 nM
Compound 4: middle estimate off by 1.4-fold (0.15 log units), on the high side; the measured number falls inside the stated range.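

In this assay, among these compounds, the change from naphthalen-2-yl to thiophen-2-yl on the carbonyl carbon gives a 1.4-fold lower number from compound 1 to compound 4 (0.15 log units; within the scatter) as the only step at this position that joins two exact readings. Against 4-chlorophenyl and 3,5-difluorophenyl there are only floors, an at least 1.4-fold lower number from compound 3 to compound 4 (0.16 log units; that floor lies within the scatter) and an at least 1.4-fold lower number from compound 2 to compound 4 (0.16 log units; that floor lies within the scatter), so a larger step cannot be excluded. Compound 2 and compound 3 each stand at a limit of the assay, not a number: the limit of > 225000 nM in this assay, at which 2 of the 4 values shown sit.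

From the compounds shown here alone, how far those two compounds truly lie from compound 4 stays open. So does whether an amine or a carboxylic acid on this carbonyl carbon would give a step beyond the scatter.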